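Cyano and Nitro Benzyl Ethers on the Shared Core: Cytotoxicity

A few compounds are considered here, and "the series" means these few. Any claim that something is new, unique, unknown or untested is made for them only; others in the source may bear on it.

Measured compounds:
compound 1 `N#Cc1ccccc1COc1c(-c2ccccc2)oc2cc(O)cc(O)c2c1=O` — > 100000 nM
compound 2 `O=c1c(OCc2ccccc2[N+](=O)[O-])c(-c2ccccc2)oc2cc(O)cc(O)c12` — 51000 nM
compound 3 `N#Cc1cccc(COc2c(-c3ccccc3)oc3cc(O)cc(O)c3c2=O)c1` — 21000 nM

In an ADME assay on Huh-5-2 cells (Homo sapiens) for cytotoxicity, read by WST assay, with a stated time of 3 days (on this read-out lower numbers stand for higher toxicity in this test and higher numbers for lower toxicity in this test), compound 1 sits at the limit of the test, > 100000 nM, which is a limit and not a number (the limit of > 100000 nM in this assay, at which 1 of the 3 values shown sits). In this assay compound 2 gives 51000 nM and compound 3 gives 21000 nM, the lowest number among the measured pair, with a 2.4-fold lower number from compound 2 to compound 3 (0.39 log units; beyond the scatter).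

The two cores differ as 3-cyanophenyl in place of 2-cyanophenyl on a saturated chain carbon bound to an oxygen on an aromatic ring, and that change gave an at least 4.7-fold lower number from compound 1 to compound 3 (0.67 log units; beyond the scatter).

The change carried to the new compound has one measured precedent: nitro in place of cyano on an aromatic carbon gave an at least 1.9-fold lower number from compound 1 to compound 2 (0.29 log units; that floor lies within the scatter), a floor set by the limit of compound 1. Compound 4 `O=c1c(OCc2cccc([N+](=O)[O-])c2)c(-c2ccccc2)oc2cc(O)cc(O)c12` arises from compound 3 by nitro in place of cyano on an aromatic carbon. It is the same kind of change, not the same: in compound 1 the group sits ortho to a large group, in compound 3 meta to a large group.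

For compound 4 a step of about that floor is expected, a 1.6-fold lower number from compound 3 to compound 4 (0.21 log units; within the scatter), resting on the precedent an at least 1.9-fold lower number from compound 1 to compound 2 (0.29 log units; that floor lies within the scatter). Compound 4 is therefore estimated at 13000 nM, between 6000 nM and 35000 nM.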

Compound 4, half-maximal cytotoxic concentration: 31000 nM
Estimate against measurement, compound 4: 2.4-fold (0.38 log units) below; the measured number falls inside the stated range.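

Nitro in place of cyano on an aromatic carbon does not carry over as one fixed step between these cores in this assay: the same change on two cores in this assay, an at least 1.9-fold lower number (0.29 log units; that floor lies within the scatter) from compound 1 to compound 2 and a 1.5-fold higher number (0.17 log units; within the scatter) from compound 3 to compound 4, at least 2.8-fold (0.46 log units) apart, beyond the scatter of two such steps

On the core of compound 3 the change gives a 1.5-fold higher number from compound 3 to compound 4 (0.17 log units; within the scatter), 3-nitrophenyl in place of 2-nitrophenyl gives a 1.6-fold lower number from compound 2 to compound 4 (0.22 log units; within the scatter), and 3-nitrophenyl in place of 2-cyanophenyl gives an at least 3.2-fold lower number from compound 1 to compound 4 (0.50 log units; beyond the scatter), the last being a floor only. Compound 1 gives > 100000 nM, which is a limit and not a number, and these four compounds show neither the true size of the gap between the two steps nor a reversal in the direction of the change.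

Still open, on these data alone, is how an amine or a carboxylic acid in place of cyano or nitro on the same aromatic carbon would read in this assay. Also open, as far as these compounds go, is whether a longer chain between the ether oxygen and the aromatic ring would shift these steps.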